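Removing a methoxy from the 3,4-dimethoxyphenyl group

The source may report more compounds than this note shows. Statements on the series, on what has been measured and on what is new or still open speak of the compounds shown alone.

Among the measured compounds shown here, in a functional assay on THP-1 cells (Homo sapiens) for inhibition, read by sulforhodamine B assay, with a stated time of 48 h, tested at 50 uM (a higher number here means more inhibition of growth at the concentration tested, a lower number less inhibition of growth), compound 1 (`COc1ccccc1/C=C/C(=O)/C=C/c1ccc(OCc2cn(CCCOc3cc(=O)oc4ccccc34)nn2)c(OC)c1`) gives 50%, and compound 2 (`COc1ccc(/C=C/C(=O)/C=C/c2ccc(OCc3cn(CCCOc4cc(=O)oc5ccccc45)nn3)c(OC)c2)cc1OC`) gives 73%, the higher of the two numbers so far. For the measured compounds named here, the only measured step is a number 23 percentage points higher from compound 1 to compound 2 (beyond the scatter), with 3,4-dimethoxyphenyl in place of 2-methoxyphenyl. Compound 3 (`COc1ccc(/C=C/C(=O)/C=C/c2ccc(OCc3cn(CCCOc4cc(=O)oc5ccccc45)nn3)c(OC)c2)cc1`) differs from compound 2 by hydrogen in place of methoxy on an aromatic carbon, turning 3,4-dimethoxyphenyl into 4-methoxyphenyl. The measured step bears on this change only in part. Going by the values given here, it concerns the same end of the molecule, but no measured pair isolates the loss of this methoxy. A lower number is expected, since compound 1, which also lacks the 3,4-dimethoxyphenyl group, stands at 50%. The estimated change is a number 13 percentage points lower from compound 2 to compound 3 (beyond the scatter), a modest fall. For compound 3 the estimated value is 60%, with an expected range of 46% to 74%.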

Compound 3, percent growth inhibition at one concentration: 56%
Compound 3: middle estimate off by 4 percentage points, on the high side, and the stated range covers the measured number.
By their numbers in this assay, from the lowest: compounds 1 and 3 (each within the scatter of the next); then compound 2.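

In this assay, the methoxy lost from the 3,4-dimethoxyphenyl group now has a reading of its own: a number 17 percentage points lower from compound 2 to compound 3 (beyond the scatter), for a change on an aromatic carbon ortho to a methoxy group. With one methoxy on the ring, the 4-methoxyphenyl and 2-methoxyphenyl groups are not separated, with a number 6 percentage points higher from compound 1 to compound 3 (within the scatter), so among these three compounds only the 3,4-dimethoxyphenyl group stands apart. No supporting measurement is available to explain this difference.

Going by these compounds, it remains open whether the higher number of compound 2 depends on methoxy itself or would also hold with a hydroxyl or an amine on that aromatic carbon. The effect of a longer alkoxy chain there is also unresolved.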